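The compounds below may be only part of what the source reports. "The series", "measured", "known", "first", "only" and "open" are said of these compounds alone.

Compound 1 `C[C@@H]1CN(c2ncccc2C(F)(F)F)CCN1C(=O)Nc1ccc(C(F)(F)F)cc1` gives 11 nM in a functional assay for antagonist activity at transient receptor potential cation channel subfamily V member 1 (Rattus norvegicus); a higher number here means a weaker inhibitor, a lower number a stronger inhibitor. Compound 2 `Cc1cccnc1-c1ccc(C(=O)Nc2ccc(C(C)C)cc2)cc1` gives 43 nM. Compound 3 `Cc1cccnc1-c1ccc(C(=O)Nc2ccc(F)cc2)cc1` gives only a limit, > 4000 nM, so its true value is not pinned down.

Going by the values given here, compound 3 thus stands at the edge of what this assay reports; it is the one value here recorded as a limit (the limit of > 4000 nM in this assay, at which 1 of the 3 values shown sits). Compound 4 `Cc1cccnc1-c1ccc(C(=O)Nc2ccc(Cl)cc2)cc1` differs from it in one place: chloro in place of fluoro on an aromatic carbon. Among the compounds with values here, the only measured step that bears on this position is an at least 93-fold higher number from compound 2 to compound 3 (1.96 log units; beyond the scatter), showing that the group at this place can swing the result greatly. Whether chloro recovers part of that loss is not shown, so compound 4 is expected to gain modestly, an at least 2.6-fold lower number from compound 3 to compound 4 (0.42 log units; beyond the scatter), with a real chance of meeting the limit again. Compound 4 is estimated at 1500 nM, between 300 nM and 6000 nM.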

Compound 4, half-maximal inhibitory concentration: 2020 nM
Compound 4: the middle estimate sits 1.3-fold (0.13 log units) below what was measured; the measured number falls inside the stated range.
By their numbers in this assay, from the lowest: compound 1; then compound 2; then compound 4. At a limit, above all of these: compound 3.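

Compound 3 is recorded only as a limit in this assay: the limit of > 4000 nM in this assay, at which 1 of the 4 values shown sits. Chloro in place of fluoro gives an at least 1.9-fold lower number from compound 3 to compound 4 (0.29 log units; that floor lies within the scatter), so these numbers cannot establish a real gain for chloro over fluoro. Isopropyl remains well ahead of chloro at this place, with a 47-fold higher number from compound 2 to compound 4 (1.67 log units; beyond the scatter), so the large drop from isopropyl is not confined to fluoro.

Still open, from the compounds shown here alone, is how a methoxy or tert-butyl group would read at this place on the shared core. Compound 1 differs from the others in more than one place, so it does not help answer this.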